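Bromo for acetyl on the urea aryl ring

The source may report more compounds than this note shows. Statements on the series, on what has been measured and on what is new or still open speak of the compounds shown alone.

Compound 2 `CC(=O)c1ccccc1NC(=O)N[C@@H](C)c1ccccc1` was measured in an ADME assay on the whole organism with Oryza sativa as the target, tested at 10 uM (a higher number here means a weaker effect of the compound at the concentration tested, a lower number a stronger effect), and gives 96%. Its closest relative among the measured compounds is compound 1 `C[C@H](NC(=O)Nc1ccccc1C(F)(F)F)c1ccccc1`, which in this assay gives 97%; the two numbers lie within the scatter of each other, so compound 2 stands beside compound 1 rather than apart from it. For the measured compounds named here, the only measured step, a number 1 percentage points lower from compound 1 to compound 2 (within the scatter), is therefore also within the scatter.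

Compound 3 `C[C@H](NC(=O)Nc1ccccc1Br)c1ccccc1` has not yet been measured in this assay. It differs from compound 2 as follows: bromo in place of acetyl on an aromatic carbon. Going by the values given here, no measured step exchanges an acetyl for a bromo, so the only guide is the step from compound 1 to compound 2, where a change at the same place on the aromatic carbon left the read-out unchanged beyond the scatter. On that basis compound 3 is expected to show a step of no change at the digits printed from compound 2 to compound 3 (within the scatter), that is, no change beyond the scatter. Compound 3 is estimated at 96% in this assay, with a range from 87% to 100%.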

Compound 3, a percentage reported as activity, at one concentration (the size of the read-out at that concentration, not a potency): 102%
Estimate against measurement, compound 3: 6 percentage points below, and the stated range ends below it.
By their numbers in this assay, from the lowest: compounds 2, 1 and 3 (each within the scatter of the next).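

In this assay bromo gives a number 6 percentage points higher from compound 2 to compound 3 (within the scatter) and a number 5 percentage points higher from compound 1 to compound 3 (within the scatter) on the same aromatic carbon, so all three groups placed there so far, trifluoromethyl, acetyl and bromo, lie within the scatter of one another. This is the first exchange at this position in which a group of 3 heavy atoms carrying a double bond and a hydrogen-bond acceptor gives way to a single bromine atom with no hydrogen-bond acceptor, and among these three compounds that difference does not separate the read-outs. Nothing measured here offers a reason for this result or shows what the read-out reflects in the whole organism.

For the compounds shown here, no step at this position yet lies beyond the scatter, so the three compounds do not show whether the read-out can respond to a change at this aromatic carbon at all. As far as these compounds go, it remains open whether an amine, a carboxylic acid or a methoxy group in this place, or a change elsewhere on the shared core, would set a compound apart from these three.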